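Swapping an aryl for a benzyloxy group on the core

This account rests on a few compounds, and the source may have more. Where it says the series, first, only, none or still open, it means among the compounds named here.

Measured compounds:
Compound 1 `Cc1nn(-c2ncnc3nc[nH]c23)c2c1C(c1ccc(F)cc1Cl)CC(=O)N2` gives 280 nM in a functional assay on HEK293 cells for agonist activity at G-protein coupled receptor 39 (Homo sapiens), read by scintillation proximity assay and inositol phosphate accumulation, with a stated time of 75 min; a higher number here means that more compound is needed for the effect, a lower number that less compound is needed.
Compound 2 `Cc1cc(C)nc(-n2nc(C)c3c2NC(=O)CC3c2ccc(F)cc2F)n1` gives only a limit in this assay, > 10000 nM.

Among the compounds with values here, compound 1 is the only compound with a number in this assay; the other result, (the limit of > 10000 nM in this assay, at which 1 of the 2 values shown sits), is a limit and not a number. Compound 3 `Cc1nn(-c2ncnc3nc[nH]c23)c2c1C(OCc1ccc(Cl)cc1Cl)CC(=O)N2` differs from compound 1 in one place: (2,4-dichlorobenzyl)oxy in place of 2-chloro-4-fluorophenyl on a saturated ring carbon. Within the data shown here, no measured step of this kind is available, so the direction rests on expectation alone; a result weaker than compound 1, beyond the usual scatter, is expected. Compound 3 is estimated to give 2500 nM, between 400 nM and 10000 nM. This corresponds to an expected step of an 8.9-fold higher number from compound 1 to compound 3 (0.95 log units; beyond the scatter).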

Compound 3, half-maximal effective concentration: 243 nM
Compound 3: the middle estimate sits 10-fold (1.01 log units) above what was measured, outside the stated range (below it).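

Putting (2,4-dichlorobenzyl)oxy in place of 2-chloro-4-fluorophenyl on the saturated ring carbon gives a 1.2-fold lower number from compound 1 to compound 3 (0.06 log units; within the scatter) in this assay. Compound 1 alone could not show whether this carbon accepts any change; the step shows that it accepts a larger group joined through oxygen with no difference beyond the scatter. Nothing measured here bears on the cause of this result.

From the compounds shown here alone, both groups carry a chlorinated benzene ring, so whether that ring is needed stays open. A simple methyl, an amine or a carboxylic acid on this carbon would test it.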